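A dichlorophenyl variant of compound 2

The source may hold more compounds than are shown below. What is called first, only, known or untested is meant among the compounds shown, and "the series" means these compounds.

Among the measured compounds shown here, compound 2 `COc1ccc(-n2nc(C(=O)Nc3ccc(Oc4ccnc5cc(OCCCN6CCCCC6)c(OC)cc45)c(F)c3)c(C)cc2=O)cc1` gives 330 nM in a functional assay on MKN-45 cells (Homo sapiens) for inhibition, read by MTT assay, with a stated time of 72 h (on this read-out higher numbers stand for weaker inhibition and lower numbers for stronger inhibition), the higher of the two numbers so far; its nearest neighbour, compound 1 `COc1cc2c(Oc3ccc(NC(=O)c4nn(-c5cccc(F)c5)c(=O)cc4C)cc3F)ccnc2cc1OCCCN1CCCCC1`, gives 130 nM in this assay. For the measured compounds named here, the one step between them, a 2.5-fold higher number from compound 1 to compound 2 (0.40 log units; beyond the scatter), was modest and beyond the scatter. Compound 3 `COc1cc2c(Oc3ccc(NC(=O)c4nn(-c5ccc(Cl)cc5Cl)c(=O)cc4C)cc3F)ccnc2cc1OCCCN1CCCCC1` carries 2,4-dichlorophenyl in place of 4-methoxyphenyl on an aromatic nitrogen. Going by the values given here, only that step bears on this change, and it ran from the 3-fluorophenyl of compound 1 toward the 4-methoxyphenyl; compound 3 leaves the 4-methoxyphenyl again, so a modest step toward a lower number is expected, a 2.1-fold lower number from compound 2 to compound 3 (0.31 log units; beyond the scatter). Compound 3 is therefore estimated at 160 nM in this assay, within 60 nM to 450 nM.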

Compound 3, half-maximal inhibitory concentration: 80 nM
Compound 3: middle estimate off by 2.0-fold (0.30 log units), on the high side; low and high end bracket the measured number.
By their numbers in this assay, from the lowest: compounds 3 and 1 (each within the scatter of the next); then compound 2.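

Leaving the 4-methoxyphenyl on the aromatic nitrogen gives a 4.1-fold lower number from compound 2 to compound 3 (0.62 log units; beyond the scatter) in this assay, so this position responds to a second replacement of that group, not only to the 3-fluorophenyl. The 2,4-dichlorophenyl and the 3-fluorophenyl cannot be told apart here, with a 1.6-fold lower number from compound 1 to compound 3 (0.21 log units; within the scatter), and compound 2 alone stands off from both. No measurement at hand accounts for this difference. Open, going by these compounds, is how a single chlorine, as in 4-chlorophenyl, or an unsubstituted phenyl would read at this nitrogen. Also open, on these data alone, is whether a pyridine ring or a cyclohexyl group would be tolerated there.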